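This account rests on a few compounds, and the source may have more. Where it says the series, first, only, none or still open, it means among the compounds named here.

The series shares one core, and the compounds differ in the aryl group attached to it. Compound 1 `COc1cc(-n2cnc3ccc(-c4ccc([N+](=O)[O-])cc4)cc32)cc(OC)c1OC` carries a 4-nitrophenyl group, and in a functional assay on SGC-7901 cells (Homo sapiens) for antiproliferative activity, read by MTT assay, with a stated time of 72 h (a higher number here means a weaker inhibitor, a lower number a stronger inhibitor), compound 1 gives 79 nM. Compound 2 `COc1cc(-n2cnc3ccc(-c4cccc(F)c4)cc32)cc(OC)c1OC` carries a 3-fluorophenyl group at the same place, and in this assay compound 2 gives 2490 nM, the highest of the two numbers recorded. Within the data shown here, the only single change measured so far is a 32-fold higher number from compound 1 to compound 2 (1.50 log units; beyond the scatter). Compound 3 `COc1cc(-c2ccc3ncn(-c4cc(OC)c(OC)c(OC)c4)c3c2)cc(OC)c1OC` gives in this assay only a limit of the assay, > 10000 nM. the limit of > 10000 nM in this assay, at which 1 of the 3 values shown sits, marks where that limit sits.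

Compound 4 `COc1cc(-n2cnc3ccc(-c4cc(F)ccc4F)cc32)cc(OC)c1OC` differs from compound 2 by fluoro in place of hydrogen on an aromatic carbon, so that the 3-fluorophenyl group becomes 2,5-difluorophenyl. Among the measured compounds shown here, no measured step adds a fluoro to a ring that already carries one: the single measured step, a 32-fold higher number from compound 1 to compound 2 (1.50 log units; beyond the scatter), exchanged one aryl group for another, and compound 3 offers only a limit. There is thus no measured basis for expecting a step beyond the scatter. A step of a 1.1-fold lower number from compound 2 to compound 4 (0.05 log units; within the scatter) is expected in this assay, within the scatter and in no fixed direction. For compound 4 the estimate in this assay is 2200 nM, between 700 nM and 7000 nM.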

Compound 4, half-maximal inhibitory concentration: 6590 nM
For compound 4 the middle estimate is 3.0-fold (0.48 log units) below the measured one, and the stated range covers the measured number.
By their numbers in this assay, from the lowest: compound 1; then compound 2; then compound 4. At a limit, above all of these: compound 3.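

In this assay, fluoro in place of hydrogen, ortho to a large group and para to a fluoro group, gives a 2.6-fold higher number from compound 2 to compound 4 (0.42 log units; beyond the scatter). Among these compounds, this is the first measured change that adds one atom to an aryl group already present rather than exchanging the whole group, and it shows that even this small addition to the 3-fluorophenyl ring moves the number beyond the scatter, upward. Measured against the 4-nitrophenyl group, 2,5-difluorophenyl gives an 83-fold higher number from compound 1 to compound 4 (1.92 log units; beyond the scatter), so both fluorinated aryl groups, in compound 2 and compound 4, stand well above compound 1, and the second fluoro widens that distance rather than closing it.

Nothing given here accounts for the rise on adding fluoro, and no measurement shown bears on its cause. Left open is how the same core would stand in this assay with an unsubstituted phenyl ring, or with an aryl group carrying an amine or a carboxylic acid, and so whether the low number of compound 1 belongs to the nitro group itself.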